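The source may hold more compounds than are shown below. What is called first, only, known or untested is meant among the compounds shown, and "the series" means these compounds.

Compound 1 `N#Cc1ccc(OC2CCN(C(=O)Nc3cc(-c4ccccn4)n[nH]3)CC2)cc1`: 14.7 mL.min-1.g-1
Compound 2 `O=C(Nc1cc(-c2ccccn2)n[nH]1)N1CCN(c2ccc(F)cc2)CC1`: 30.8 mL.min-1.g-1
Compound 3 `O=C(Nc1cc(-c2ccccn2)n[nH]1)N1CCC(c2cccc(Cl)c2)CC1`: not yet measured

In an ADME assay on liver for metabolic stability, with Liver microsome (Homo sapiens) as the target, using microsomes (a lower number here means slower removal, a higher number faster removal of the compound), compound 1 gives 14.7 mL.min-1.g-1, the lower of the two numbers, and the gap to compound 2 lies beyond the scatter. Compound 3 carries 3-chlorophenyl in place of 4-cyanophenoxy on a saturated ring carbon. Among the measured compounds shown here, no measured pair differs in one place, so the step size in this assay is uncertain. An upward step is expected, with compound 2 at 30.8 mL.min-1.g-1 as the only higher reference. The estimated step is a 2.0-fold higher number from compound 1 to compound 3 (0.31 log units; beyond the scatter). For compound 3 the expected value is 30 mL.min-1.g-1, with an estimated range of 14 mL.min-1.g-1 to 65 mL.min-1.g-1.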

Compound 3, intrinsic clearance in microsomes: 30.8 mL.min-1.g-1
Estimate against measurement, compound 3: 1.0-fold (0.01 log units) below, and the stated range covers the measured number.
By their numbers in this assay, from the lowest: compound 1; then compounds 2 and 3 (each within the scatter of the next).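

In this assay, among the compounds shown here, the first comparison that differs in one place gives a 2.1-fold higher number from compound 1 to compound 3 (0.32 log units; beyond the scatter) as 4-cyanophenoxy leaves and 3-chlorophenyl enters. The number can therefore shift with the group held by this carbon of the six-membered ring with 1 nitrogen, although this modest step rests on a single pair. Nothing available accounts for the step. Still open, going by these compounds, is whether 4-cyanophenyl or 3-chlorophenoxy at this carbon would separate the contribution of the ring substituent from that of the ether oxygen. On these data alone, how an amine or a carboxylic acid at the same carbon would read here also remains open.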